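Adding a Methyl to the Chain in a Fluorinated Analogue

The source may report more compounds than this note shows. Statements on the series, on what has been measured and on what is new or still open speak of the compounds shown alone.

Measured so far in an assay on mitochondria from L6 cells (Rattus norvegicus) for activation, with a stated time of 90 min; a higher number here means that more compound is needed for the effect, a lower number that less compound is needed:
compound 1 `CCCCc1ccc(Nc2nc3nonc3nc2O)cc1` gives 2100 nM
compound 2 `CCCCCc1ccc(Nc2nc3nonc3nc2O)cc1` gives 2400 nM
compound 3 `CCCCc1ccc(Nc2nc3nonc3nc2O)c(F)c1` gives 1100 nM

The three compounds share a core and differ only at the edges. Compound 2 differs from compound 1 by methyl in place of hydrogen on a saturated chain carbon, four bonds along the chain from an aromatic carbon, and this step shows a 1.1-fold higher number from compound 1 to compound 2 (0.06 log units; within the scatter), so lengthening the chain by one carbon left the result essentially unchanged. Compound 3 differs from compound 1 by fluoro in place of hydrogen on an aromatic carbon, and this step shows a 1.9-fold lower number from compound 1 to compound 3 (0.28 log units; within the scatter); the two values cannot be ordered with confidence. The gap between compound 2 and compound 3 is wider than the scatter, but no single change connects those two.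

Compound 4 `CCCCCc1ccc(Nc2nc3nonc3nc2O)c(F)c1` has not yet been measured. It differs from compound 3 by methyl in place of hydrogen on a saturated chain carbon, four bonds along the chain from an aromatic carbon, which is the same change that leads from compound 1 to compound 2, made on a core that carries the fluoro group of compound 3 rather than the hydrogen of compound 1. Because a 1.1-fold higher number from compound 1 to compound 2 (0.06 log units; within the scatter) was within the scatter, the expectation for compound 4 is a similarly small step, a 1.1-fold higher number from compound 3 to compound 4 (0.04 log units; within the scatter), with the fluoro group assumed not to alter how the chain extension reads out. The estimate for compound 4 in this assay is therefore 1200 nM, with a plausible range from 600 nM to 2400 nM.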

Compound 4, half-maximal effective concentration: 1500 nM
For compound 4 the middle estimate is 1.3-fold (0.10 log units) below the measured one, within the range that was stated.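

In this assay, putting methyl in place of hydrogen on the chain of the fluorinated core gives a 1.4-fold higher number from compound 3 to compound 4 (0.13 log units; within the scatter), and this step agrees with the one seen for the same change on the core without fluoro: the same change on two cores in this assay, a 1.1-fold higher number (0.06 log units; within the scatter) from compound 1 to compound 2 and a 1.4-fold higher number (0.13 log units; within the scatter) from compound 3 to compound 4, 1.2-fold (0.08 log units) apart, within the scatter of two such steps Fluoro in place of hydrogen on the aromatic carbon, now made on the core with the longer chain, gives a 1.6-fold lower number from compound 2 to compound 4 (0.20 log units; within the scatter), and this step also agrees with its earlier counterpart: the same change on two cores in this assay, a 1.9-fold lower number (0.28 log units; within the scatter) from compound 1 to compound 3 and a 1.6-fold lower number (0.20 log units; within the scatter) from compound 2 to compound 4, 1.2-fold (0.08 log units) apart, within the scatter of two such steps Across these four compounds, each change therefore reads the same on both cores, but all four steps are within the scatter, so this shows that small steps stayed small and not that a clear gain or loss carries from one core to another.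

The compounds shown leave open whether the two changes would still carry over on a core that differs in some other way, or for a change that produces a step beyond the scatter. They also leave open how a longer chain, an amine or a carboxylic acid in place of the chain, or chloro in place of fluoro would read out in this assay.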